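The compounds below may be only part of what the source reports. "The series", "measured", "known", "first", "only" and "open" are said of these compounds alone.

Compound 1, with the structure `CC1=CC[C@H](C(C)C)c2cc(C)c(OC(=O)Nc3ccccc3)cc21`, has the highest number of the three compounds measured in a functional assay on HCT-15 cells (Homo sapiens) for antiproliferative activity, read by sulforhodamine B assay, with a stated time of 48 h, tested at 50 uM; on this read-out higher numbers stand for more inhibition at the one concentration tested (going by the name of the read-out) and lower numbers for less inhibition: compound 1 gives 92%, well beyond the usual scatter above the other two. Compound 2, `Cc1cc2c(C(C)C)ccc(C)c2cc1OC(=O)c1ccc(C(F)(F)F)cc1`, gives 55.6% in this assay, and compound 3, `COc1cccc(C(=O)Oc2cc3c(C)ccc(C(C)C)c3cc2C)c1`, gives 35.2%. Both of those carry an ester link on a different core, so they only hint at what an ester might do.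

Compound 4, `CC1=CC[C@H](C(C)C)c2cc(C)c(OC(=O)c3cccc([N+](=O)[O-])c3)cc21`, keeps the core of compound 1 and changes only the group on the carbonyl carbon: 3-nitrophenyl in place of anilino on a carbonyl carbon. Within the data shown here, no measured pair shows exactly this exchange of anilino for an aromatic ester group, so the step from compound 1 to compound 4 has to be guessed. Given that compound 2 with its ester link reaches only 55.6% and compound 3 with its ester link reaches only 35.2%, a drop is expected; I estimate a number 32 percentage points lower from compound 1 to compound 4 (beyond the scatter). Compound 4 is therefore expected to give about 60%, somewhere between 35% and 88%.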

Compound 4, a percentage reported as inhibition, at one concentration (the size of the read-out at that concentration, not a potency): 45.9%
Beside the measured number, compound 4's estimate is 14.1 percentage points above it; low and high end bracket the measured number.
By their numbers in this assay, from the lowest: compound 3; then compounds 4 and 2 (each within the scatter of the next); then compound 1.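

On the core of compound 1, the group on the carbonyl carbon has a strong effect on the read-out in this assay: 3-nitrophenyl in place of anilino gives a number 46.1 percentage points lower from compound 1 to compound 4 (beyond the scatter) and so shows on a single core what the ester compounds on the other core could only hint at. This one exchange alters two features together, the nitrogen that joins the ring to the carbonyl carbon and the nitro group on the ring, so the step cannot be assigned to either feature alone. Nothing available here explains the drop.

A plain phenyl group on the carbonyl carbon, or an anilino group bearing a nitro group, would help to separate those two features. Going by these compounds, what a morpholine ring or a longer alkyl chain would give at this place also remains open.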